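The source may hold more compounds than are shown below. What is called first, only, known or untested is meant among the compounds shown, and "the series" means these compounds.

Compound 2 `Cc1cccc(-n2nncc2CN2C(=O)C3(C(C#N)=C(N)Oc4c(N)cc5nc6ccccc6nc5c43)c3ccccc32)c1` is tested in a functional assay on A549 cells (Homo sapiens) for antiproliferative activity, read by MTT assay, with a stated time of 48 h (a higher number here means a weaker inhibitor, a lower number a stronger inhibitor), where compound 2 gives 12300 nM. Compound 1 `N#CC1=C(N)Oc2c(c3nc4ccccc4nc3c3ccccc23)C12C(=O)N(Cc1cnnn1-c1ccc(N)cc1)c1ccccc12` gives > 50000 nM in this assay, which is a limit of the assay and not a number, since it sits at the limit of > 50000 nM in this assay, at which 1 of the 2 values shown sits. Among the measured compounds shown here, compound 2 therefore holds the only number among the two values at hand, and it stands at a weak level. Compound 3 `CCOc1ccc(-n2nncc2CN2C(=O)C3(C(C#N)=C(N)Oc4c(N)cc5nc6ccccc6nc5c43)c3ccccc32)cc1` carries 4-ethoxyphenyl in place of 3-methylphenyl on an aromatic nitrogen. For the measured compounds named here, no step between two measured compounds is available to guide the expectation, so the direction of this change cannot be read from compound 1 and compound 2. The author expects the step in this assay to be small, a 1.2-fold higher number from compound 2 to compound 3 (0.09 log units; within the scatter), within the usual scatter or only a little beyond it. Compound 3 is accordingly estimated at 15000 nM, with a range from 5000 nM to 45000 nM, and with a real chance that this assay reports only a limit.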

Compound 3, half-maximal inhibitory concentration: > 50000 nM
Compound 3: only a limit was reported (the forecaster's own chance of this, stated with the estimate: 25%); at least 3.3-fold (0.52 log units) between middle value and limit.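

In this assay compound 3 gives > 50000 nM, which is a limit of the assay and not a number. Among the compounds shown here, the substituent on the phenyl group at this aromatic nitrogen of the five-membered ring is thus not indifferent: 4-ethoxyphenyl in place of 3-methylphenyl gives an at least 4.0-fold higher number from compound 2 to compound 3 (0.60 log units; beyond the scatter), the first step that can be read at this position. The true size of that step stays unknown, because the read-out ends at a limit: the limit of > 50000 nM in this assay, at which 2 of the 3 values shown sit.

The two groups differ both in the substituent and in where it sits on the phenyl ring, so it stays open which of these accounts for the step. The compounds shown also do not tell how a 3-ethoxyphenyl, a 4-methylphenyl or an unsubstituted phenyl group would read in this assay.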